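Compound 1 to compound 4: 4-fluorophenyl replacing 2-hydroxyphenyl

The source may report more compounds than this note shows. Statements on the series, on what has been measured and on what is new or still open speak of the compounds shown alone.

Values in a functional assay on A549 cells (Homo sapiens) for antiproliferative activity, read by MTT assay, with a stated time of 72 h; a lower number here means a stronger inhibitor, a higher number a weaker inhibitor:
- compound 1 `Cc1nc(C)c(/C=C/C(=O)/C=C/c2ccccc2O)nc1C`: 4780 nM
- compound 2 `COc1ccccc1/C=C/C(=O)/C=C/c1nc(C)c(C)nc1C`: 3200 nM
- compound 3 `COc1ccc(/C=C/C(=O)/C=C/c2nc(C)c(C)nc2C)cc1OC`: 3790 nM

Compound 1 lies within the scatter of both compound 2 and compound 3, so the three values form a single group. The next compound, compound 4 `Cc1nc(C)c(/C=C/C(=O)/C=C/c2ccc(F)cc2)nc1C`, differs from compound 1 as follows: 4-fluorophenyl in place of 2-hydroxyphenyl on a double-bonded chain carbon bound to a double-bonded chain carbon. Among the measured compounds shown here, only one measured step bears on this change: a 1.5-fold lower number from compound 1 to compound 2 (0.17 log units; within the scatter), with methyl in place of hydrogen on an oxygen on an aromatic ring. For the measured compounds named here, no measured compound carries fluorine, so this guide is weak. No step beyond the scatter is expected in this assay. The expected change is a 1.3-fold lower number from compound 1 to compound 4 (0.10 log units; within the scatter). Compound 4 is estimated at 3800 nM, with an expected range of 1600 nM to 9000 nM.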

Compound 4, half-maximal inhibitory concentration: 5900 nM
Compound 4: the middle estimate sits 1.6-fold (0.19 log units) below what was measured; the measured number falls inside the stated range.
By their numbers in this assay, from the lowest: compounds 2, 3, 1 and 4 (each within the scatter of the next).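

In this assay, 4-fluorophenyl in place of 2-hydroxyphenyl gives a 1.2-fold higher number from compound 1 to compound 4 (0.09 log units; within the scatter) and so stays within the scatter. At this position, a value in this range therefore does not depend on the hydrogen-bond donor and acceptor counted on 2-hydroxyphenyl, and a fluorine-bearing phenyl is accepted. Nothing on hand bears on why the values stay level.

Still open, from the compounds shown here alone, is whether any change at this position moves the number beyond the scatter, for example an amine or a carboxylic acid on the phenyl ring. Going by these compounds, the role of the shared core also remains untested.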